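Swapping fluoro for chloro on a halogenated biaryl

The source may report more compounds than this note shows. Statements on the series, on what has been measured and on what is new or still open speak of the compounds shown alone.

Compound 1 `c1ccc(-c2ccc(Cn3nnc4ccccc43)cc2)cc1` carries a plain phenyl on the shared core; in an ADME assay on microsomes from liver (Mus musculus, strain NMRI) for metabolic stability, tested at 2.5 uM (on this read-out higher numbers stand for fast clearance and lower numbers for slow clearance), compound 1 gives 11.4 mL/min/g. Compound 2 `Fc1cc(Cl)ccc1-c1ccc(Cn2nnc3ccccc32)cc1` has 4-chloro-2-fluorophenyl instead, and compound 2 gives 1.1 mL/min/g, the change being a 10-fold lower number from compound 1 to compound 2 (1.02 log units; beyond the scatter). Compound 3 `Fc1cc(C(F)(F)F)ccc1-c1ccc(Cn2nnc3ccccc32)cc1` gives 1.2 mL/min/g, so the step of a 1.1-fold higher number from compound 2 to compound 3 (0.04 log units; within the scatter) stays within the scatter. Of the three measured numbers, compound 2 stands lowest, with compound 3 close by and compound 1 far above.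

Compound 4 `Clc1ccc(-c2ccc(Cn3nnc4ccccc43)cc2)c(Cl)c1` differs from compound 2 in one group: chloro in place of fluoro on an aromatic carbon, that is, 4-chloro-2-fluorophenyl to 2,4-dichlorophenyl. The swap of one halogen-type group for another on this ring, seen in compound 3, changed little, so a small step is expected here too. Compound 4 is expected to give 1 mL/min/g, between 0.5 mL/min/g and 2.2 mL/min/g. That means an expected step of a 1.1-fold lower number from compound 2 to compound 4 (0.04 log units; within the scatter), within the scatter.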

Compound 4, intrinsic clearance in a liver preparation (reported as CLH), per the amount of preparation that the assay uses: 1.3 mL/min/g
For compound 4 the middle estimate is 1.3-fold (0.11 log units) below the measured one; the range from low to high includes it.
By their numbers in this assay, from the lowest: compounds 2, 3 and 4 (each within the scatter of the next); then compound 1.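

In this assay chloro can replace fluoro at this place, ortho to a large group, with a 1.2-fold higher number from compound 2 to compound 4 (0.07 log units; within the scatter) and so no change that stands clear of the scatter. The low number therefore does not need a fluoro here, since an 8.8-fold lower number from compound 1 to compound 4 (0.94 log units; beyond the scatter) shows that 2,4-dichlorophenyl also keeps most of the drop seen from the plain phenyl. Nothing measured here explains why these halogens have this effect.

Going by these compounds, whether a methoxy group, an amine or a carboxylic acid in this place would keep the number as low remains open. So does the question of which of the two halogens on the ring accounts for more of the drop from compound 1.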